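The compounds below may be only part of what the source reports. "The series", "measured", "known", "first", "only" and "open" are said of these compounds alone.

Three compounds have numbers in an assay for inhibition of Thromboxane-A synthase (Homo sapiens), using microsomes; on this read-out higher numbers stand for weaker inhibition and lower numbers for stronger inhibition. Within the data shown here, compound 1 `N#Cc1ccc(C2OCC(C/C=C\CCC(=O)O)C(c3cccnc3)O2)cc1` gives 24 nM, and compound 2 `O=C(O)CC/C=C\CC1COC(c2ccsc2)OC1c1cccnc1` gives 500 nM; the one step between them, a 21-fold higher number from compound 1 to compound 2 (1.32 log units; beyond the scatter), is the only measured change in this set. Compound 3 `Cc1ccc(C#N)c(OC(C)(C)C2OCC(C/C=C\CCC(=O)O)C(c3cccnc3)O2)c1` gives 50 nM, which places it second highest of the three numbers: closer to compound 1, whose number is lower, and well away from compound 2, whose number is higher.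

Compound 4 `Cc1ccc(OC(C)(C)C2OCC(C/C=C\CCC(=O)O)C(c3cccnc3)O2)cc1` differs from compound 3 in one place: 4-methylphenyl in place of 2-cyano-5-methylphenyl on an oxygen on a saturated carbon. Among the measured compounds shown here, no measured step matches this change exactly. The nearest guide is the loss of the cyano-bearing ring in a 21-fold higher number from compound 1 to compound 2 (1.32 log units; beyond the scatter), which was large, though there the ring sat directly on a saturated ring carbon, whereas here it sits on an oxygen and only the cyano group and the position of the methyl change. A smaller weakening is therefore expected, giving an estimated step of a 4.0-fold higher number from compound 3 to compound 4 (0.60 log units; beyond the scatter). Compound 4 is expected to give about 200 nM, with a likely range from 60 nM to 700 nM.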

Compound 4, half-maximal inhibitory concentration: 360 nM
For compound 4 the middle estimate is 1.8-fold (0.26 log units) below the measured one, and the stated range covers the measured number.
By their numbers in this assay, from the lowest: compound 1; then compound 3; then compounds 4 and 2 (each within the scatter of the next).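

In this assay, a 7.2-fold higher number from compound 3 to compound 4 (0.86 log units; beyond the scatter) shows that the group on this oxygen matters, not only the group on the saturated ring carbon changed in the earlier step. Keeping a six-membered aromatic ring of carbon only at this place does not preserve the inhibition seen with the 2-cyano-5-methylphenyl group, so what the ring carries counts as well. No measurement presented here explains why this change weakens inhibition.

The nitrile is lost and the methyl sits differently in this single change, leaving the share of each in the step unresolved. A 2-cyanophenyl group with no methyl, or a ring carrying a methoxy group or a chlorine in place of the nitrile, would be needed to tell whether the nitrile itself is what matters here.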